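The compounds below may be only part of what the source reports. "The series", "measured", "known", "first", "only" and "open" are said of these compounds alone.

In a functional assay on SW-620 cells (Homo sapiens) for cytotoxicity, read by MTT assay, with a stated time of 72 h (a lower number here means a stronger inhibitor, a higher number a weaker inhibitor), compound 1 (`COc1cccc(/C=C2\CCC/C(=C\c3cc(OC)c(OC)c(OC)c3)C2=O)c1OC`) gives 2500 nM. Compound 2 (`COc1cc(/C=C2\CCC/C(=C\c3ccc(OC)c(OC)c3)C2=O)cc(OC)c1`) gives 2500 nM, which puts it level with compound 1. Compound 3 (`COc1ccc(/C=C2\CCC/C(=C\c3cc(OC)c(OC)c(OC)c3)C2=O)cc1OC`) has not yet been measured in this assay. It is compound 2 with one change: methoxy in place of hydrogen on an aromatic carbon. Put simply, a methoxy takes the place of a hydrogen on an aromatic carbon, and the new group sits ortho to two methoxy groups and para to a large group. For the measured compounds named here, no two measured compounds differ in just one place, so the data offer no direct guide to the effect of this change. The estimated 1.3-fold lower number from compound 2 to compound 3 (0.10 log units; within the scatter) is expected to stay within the usual scatter of this assay, with no clear direction. Compound 3 is estimated at 2000 nM, with an expected range from 700 nM to 5000 nM.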

Compound 3, half-maximal inhibitory concentration: 1800 nM
Beside the measured number, compound 3's estimate is 1.1-fold (0.05 log units) above it; the range from low to high includes it.
By their numbers in this assay, from the lowest: compounds 3, 1 and 2 (each within the scatter of the next).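

In this assay the methoxy that enters ortho to two methoxy groups and para to a large group gives a 1.4-fold lower number from compound 2 to compound 3 (0.14 log units; within the scatter) and so this position carries the added group with no clear shift in the number. Putting 3,4-dimethoxyphenyl in place of 2,3-dimethoxyphenyl gives a 1.4-fold lower number from compound 1 to compound 3 (0.14 log units; within the scatter) and so this swap also stays inside the usual scatter. For the compounds shown here, earlier, no two measured compounds differed in just one place, so these are the first direct readings, and neither shows a real gain or loss.

No outside evidence is available on why these steps are so small. Going by these compounds, it remains open whether a different group on this aromatic carbon, such as an amine or a carboxylic acid, would move the number beyond the scatter.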